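The source may report more compounds than this note shows. Statements on the series, on what has been measured and on what is new or still open speak of the compounds shown alone.

Among the compounds with values here, in a functional assay on PC-3 cells (Homo sapiens) for antiproliferative activity, read by MTT assay, with a stated time of 72 h (a higher number here means a weaker inhibitor, a lower number a stronger inhibitor), compound 2 `CC(C)/C=C/C(=O)Nc1cc2c(N3CCc4ccccc43)ncnc2cc1O[C@@H]1CCOC1` gives 11200 nM, the higher of the two numbers measured so far. Within the data shown here, its nearest neighbour, compound 1 `C=C(C)C(=O)Nc1cc2c(N3CCc4ccccc43)ncnc2cc1O[C@@H]1CCOC1`, gives 4910 nM in this assay; the only measured step, a 2.3-fold higher number from compound 1 to compound 2 (0.36 log units; beyond the scatter), is a modest move beyond the scatter. Compound 3 `CN(C)C/C=C/C(=O)Nc1cc2c(N3CCc4ccccc43)ncnc2cc1O[C@@H]1CCOC1` differs from compound 2 by (dimethylamino)methyl in place of isopropyl on a double-bonded chain carbon bound to a double-bonded chain carbon. Among the measured compounds shown here, no measured pair shows this particular exchange, so the one known step bears on it only loosely, as a sign that changing the group on the double-bonded chain carbon can shift the number by a modest amount in either direction. The step of a 3.7-fold lower number from compound 2 to compound 3 (0.57 log units; beyond the scatter) is therefore an expectation of a modest change rather than a firm prediction. Compound 3 is expected to give about 3000 nM in this assay, within a range from 800 nM to 12000 nM.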

Compound 3, half-maximal inhibitory concentration: 1230 nM
The estimate for compound 3 lay 2.4-fold (0.39 log units) above the measured number; measured number inside the range.
By their numbers in this assay, from the lowest: compound 3; then compound 1; then compound 2.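

In this assay, the step of a 9.1-fold lower number from compound 2 to compound 3 (0.96 log units; beyond the scatter) is the first change shown on the double-bonded chain carbon bound to a double-bonded chain carbon, and it replaces the all-carbon isopropyl with (dimethylamino)methyl, a group containing nitrogen. The 3-(dimethylamino)prop-1-en-1-yl group also compares well with the 1-methylethenyl group, with a 4.0-fold lower number from compound 1 to compound 3 (0.60 log units; beyond the scatter) on the carbonyl carbon, so compound 3 has the lowest number of the three and the earlier upward step now has a clear downward counterpart. Nothing available explains why this exchange goes with a lower number.

A methoxymethyl group, with oxygen in place of the nitrogen, would test whether an amine is needed at all. Piperidin-1-ylmethyl, a plain aminomethyl or a longer chain ending in dimethylamino could show how far this trend extends.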